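Carboxy to hydroxycarbamoyl on the shared core

The source may report more compounds than this note shows. Statements on the series, on what has been measured and on what is new or still open speak of the compounds shown alone.

Measured so far:
- Compound 1 `CC1CCC(=NNc2ccccc2)c2ncc(C(=O)O)c(=O)n21`; compound 1 gives 0.6 umol/kg in a functional assay on the whole organism with Rattus norvegicus as the target; on this read-out lower numbers stand for an effect already at smaller amounts and higher numbers for an effect only at larger amounts of compound
- Compound 2 `CC1CCC(=NNc2ccccc2C(=O)O)c2ncc(C(=O)O)c(=O)n21`; compound 2 gives 0.48 umol/kg in this assay

In this assay compound 1 and compound 2 lie within the scatter of each other, so compound 1 does not stand apart from compound 2 on the numbers shown. For the measured compounds named here, the one measured step, a 1.3-fold lower number from compound 1 to compound 2 (0.10 log units; within the scatter), concerns a change on an aromatic carbon and leaves the carboxy group untouched.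

Compound 3 `CC1CCC(=NNc2ccccc2)c2ncc(C(=O)NO)c(=O)n21` differs from compound 1 in that (hydroxyamino in place of hydroxy on a carbonyl carbon). Going by the values given here, no measured step touches the carbonyl carbon, so nothing in the measured pair bears directly on this change; the step from compound 1 to compound 2 shows only that the core tolerates a small change elsewhere without a shift beyond the scatter. Among the compounds with values here, with no precedent, a modest shift toward higher numbers is expected as the most likely outcome, a 2.5-fold higher number from compound 1 to compound 3 (0.40 log units; beyond the scatter), with wide uncertainty. Compound 3 is accordingly estimated at 1.5 umol/kg, within a range from 0.4 umol/kg to 6 umol/kg.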

Compound 3, dose for 50% inhibition: > 100 umol/kg
Compound 3 ended at the assay's limit; the forecaster's own chance of this, stated with the estimate: 15%; middle value at least 66-fold (1.82 log units) from the limit.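

For the compounds shown here, the carbonyl carbon carrying the carboxy group is the first place where a single change moves the read-out beyond the scatter: hydroxyamino in place of hydroxy gives an at least 160-fold higher number from compound 1 to compound 3 (2.22 log units; beyond the scatter). The change on an aromatic carbon gives only a 1.3-fold lower number from compound 1 to compound 2 (0.10 log units; within the scatter), so the tolerance seen there does not carry over to this carbonyl carbon. In this assay compound 3 stands at a limit and not at a number, so the true size of the step remains unknown: the limit of > 100 umol/kg in this assay, at which 1 of the 3 values shown sits.

The compounds shown do not tell whether this loss is particular to hydroxyamino or follows from any replacement of the hydroxy on this carbon. A primary amide, a methyl ester or a tetrazole in place of the carboxy group would separate these readings, and the cause of the loss stays open.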